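Swapping a substituted phenoxy for plain phenyl in compound 3

The source may report more compounds than this note shows. Statements on the series, on what has been measured and on what is new or still open speak of the compounds shown alone.

Compound 2 `CC(Oc1ccc(Oc2ccc(C(F)(F)F)cc2)cc1)C(=O)Cn1nnc(-c2ccc(C(=O)O)cc2)n1` was tested in an assay on microsomes from brain for inhibition of Fatty-acid amide hydrolase 1 (Rattus norvegicus), read by fluorescence and HPLC, with a stated time of 60 min (on this read-out lower numbers stand for stronger inhibition and higher numbers for weaker inhibition), where compound 2 gives 160 nM. Going by the values given here, this is the higher of the two numbers measured so far; its nearest neighbour is compound 1 `CC(Oc1ccc(Oc2ccc(Cl)cc2)cc1)C(=O)Cn1nnc(-c2ccc(C(=O)O)cc2)n1`, which in this assay gives 90 nM. Among the compounds with values here, the only single-point step among the measured pair, a 1.8-fold higher number from compound 1 to compound 2 (0.25 log units; within the scatter), changed the group on the outer ring and stayed within the scatter, so the two compounds cannot be ranked against each other.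

The step to compound 3 `CC(Oc1ccc(-c2ccccc2)cc1)C(=O)Cn1nnc(-c2ccc(C(=O)O)cc2)n1` is a different kind of change: phenyl in place of 4-(trifluoromethyl)phenoxy on an aromatic carbon. Here the whole 4-(trifluoromethyl)phenoxy group leaves and a bare phenyl enters, sitting on an aromatic carbon para to a large group. No measured step removes an oxygen-linked ring or a whole substituent in this way, so the shown data give no direct guide. Compound 3 is estimated to give 300 nM in this assay, within a range from 80 nM to 1200 nM. That estimate corresponds to an expected step of a 1.9-fold higher number from compound 2 to compound 3 (0.27 log units; within the scatter), leaning toward a weaker result but with wide uncertainty.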

Compound 3, half-maximal inhibitory concentration in the Fatty-acid amide hydrolase 1 assay: 83 nM
Compound 3: the middle estimate sits 3.6-fold (0.56 log units) above what was measured; low and high end bracket the measured number.
By their numbers in the Fatty-acid amide hydrolase 1 assay, from the lowest: compounds 3, 1 and 2 (each within the scatter of the next).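

In the Fatty-acid amide hydrolase 1 assay, taking away the whole 4-(trifluoromethyl)phenoxy group and putting a bare phenyl in its place gives a 1.9-fold lower number from compound 2 to compound 3 (0.29 log units; within the scatter), and the matching swap from the 4-chlorophenoxy group gives a 1.1-fold lower number from compound 1 to compound 3 (0.04 log units; within the scatter). The earlier pair showed only an exchange of one substituent on the outer ring, whereas these steps show that this aromatic carbon can carry a group with fewer heavy atoms and no oxygen link while the three compounds still cannot be ranked against each other. The change does register in a physicochemical assay for lipophilicity, read by HPLC, tested at 5 mM (a lower number here means a more polar compound, a higher number a more lipophilic compound), where compound 2 gives 3.5 and compound 3 gives 2.6, so compound 3 is the more polar of the pair, and in this case a clearly lower lipophilicity comes without a readable shift in inhibition: the measured partition coefficient of compound 2, 3.5, and of compound 3, 2.6, a number 0.90 log units lower (beyond the scatter)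

The compounds shown leave open whether a ring is needed on this carbon at all, as a short chain such as ethyl would test. Going by these compounds, it is also open how inhibition would respond if the phenyl carried a polar group such as an amine or a carboxylic acid.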